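This account rests on a few compounds, and the source may have more. Where it says the series, first, only, none or still open, it means among the compounds named here.

Within the data shown here, in a functional assay on MCF7 cells (Homo sapiens) for inhibition, read by sulforhodamine B assay, with a stated time of 48 h (on this read-out higher numbers stand for weaker inhibition of growth and lower numbers for stronger inhibition of growth), compound 1 `COc1cccc(C(=O)NNC(=O)c2ccc3[nH]c(-c4ccc([N+](=O)[O-])o4)nc3c2)c1` gives 15.6 ug/mL, the only true number available so far. Compound 2 `O=C(NNC(=O)c1ccc2[nH]c(-c3ccc([N+](=O)[O-])o3)nc2c1)c1cccc(Oc2ccccc2)c1` carries a phenyl in place of the methyl on the oxygen of compound 1. For compound 2 the reading is > 7.8 ug/mL, which is a limit and not a number. Compound 1 therefore has no measured neighbour to be ranked against.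

Compound 3 `COc1ccc(C(=O)NNC(=O)c2ccc3[nH]c(-c4ccc([N+](=O)[O-])o4)nc3c2)cc1OC` keeps the core of compound 1 and changes one place: methoxy in place of hydrogen on an aromatic carbon. In words, 3-methoxyphenyl becomes 3,4-dimethoxyphenyl. Among the measured compounds shown here, the only measured change that bears on this is a step that the limit leaves unreadable from compound 1 to compound 2. It concerns the existing methoxy group rather than the new position, and it offers no size to lean on. With compound 2 giving only > 7.8 ug/mL, nothing points in either direction, so no change beyond the usual scatter is expected in this assay, though this expectation is loose. The expected move is a 1.0-fold lower number from compound 1 to compound 3 (0.02 log units; within the scatter). For compound 3 the estimated value is 15 ug/mL, with an expected range from 5 ug/mL to 45 ug/mL.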

Compound 3, concentration for 50% growth inhibition: 31.3 ug/mL
Estimate against measurement, compound 3: 2.1-fold (0.32 log units) below; the measured number falls inside the stated range.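

Adding a methoxy group to the six-membered aromatic ring of compound 1, ortho to the existing methoxy group and para to a large group, gives a 2.0-fold higher number from compound 1 to compound 3 (0.30 log units; within the scatter) in this assay. This is the first step among these compounds that can be read as a size, and it shows that on this read-out 3-methoxyphenyl and 3,4-dimethoxyphenyl cannot be told apart, so this position takes a methoxy group with no change beyond ordinary repeat-to-repeat variation. Among these compounds, it is a single pair, so it describes only this change on the core of compound 1 and sets no rule for other groups.

The steps involving compound 2 cannot be read, because its reading is a limit and not a number: the limit of > 7.8 ug/mL in this assay, at which 1 of the 3 values shown sits.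

Whether a different group at this same position, such as a hydroxyl, an amine or a carboxylic acid, would move the number beyond the scatter remains open, as does the reason why the methoxy group leaves the reading within it.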